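A few compounds are considered here, and "the series" means these few. Any claim that something is new, unique, unknown or untested is made for them only; others in the source may bear on it.

Of the compounds shown here, two from this series have been tested in a functional assay on RPMI18226 cells (Homo sapiens) for antiproliferative activity, read by sulforhodamine B assay, with a stated time of 48 h, tested at 10 uM (on this read-out lower numbers stand for less inhibition and higher numbers for more inhibition at the one concentration tested (going by the name of the read-out)), so far. Compound 1 `Cc1ccc(NC(=O)c2c(-c3ccc(Cl)cc3)cc(-c3ccccc3)nc2N2CCCCC2)cc1` gives 24% in this assay. Compound 2 `Nc1nc(-c2ccccc2)cc(-c2ccc(Cl)cc2)c1C(=O)Nc1ccccc1` gives 46% in this assay, which is the higher of the two numbers; compound 1 stands a distance below it that lies beyond the usual scatter. Among the compounds with values here, no single-change step between these two has been worked out, so the pair can only be read as two values side by side.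

The next compound, compound 3 `Cc1ccc(NC(=O)c2c(-c3ccc(Cl)cc3)cc(-c3ccccc3)nc2N)cc1`, is reached from compound 2 by one change: methyl in place of hydrogen on an aromatic carbon. Nothing measured in this set shows directly what this change does, so any expectation has to rest on compound 2 alone. On that basis the step from compound 2 to compound 3 in this assay is expected to be small, a number 4 percentage points lower from compound 2 to compound 3 (within the scatter), with no clear direction beyond the scatter. Compound 3 is therefore estimated to give 42% in this assay, within a range from 22% to 62%.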

Compound 3, a percentage reported as inhibition, at one concentration (the size of the read-out at that concentration, not a potency): 71%
Compound 3: the middle estimate sits 29 percentage points below what was measured, and the stated range ends below it.
By their numbers in this assay, from the lowest: compound 1; then compound 2; then compound 3.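

In this assay, the change from phenylcarbamoyl to (4-methylphenyl)carbamoyl gives a number 25 percentage points higher from compound 2 to compound 3 (beyond the scatter), so a single methyl at this place, para to a large group, moves the read-out beyond the scatter. Compound 3 also makes a second single change readable: amino in place of piperidin-1-yl on an aromatic carbon gives a number 47 percentage points higher from compound 1 to compound 3 (beyond the scatter), which shows that, with the (4-methylphenyl)carbamoyl group held constant, these two groups are not interchangeable in this series. No measurement at hand accounts for either step.

Methyl is the only group seen at this place, so it remains open whether a chlorine atom, a methoxy group or an ethyl group there would read the same way, and whether the methyl step would carry over to a compound bearing piperidin-1-yl instead of amino. From the compounds shown here alone, how groups such as methylamino or morpholin-4-yl would read in place of the amino, and so how far the read-out follows the group at that carbon, also stays open.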